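The compounds below may be only part of what the source reports. "The series", "measured", "known", "first", "only" and "open" are said of these compounds alone.

Measured so far:
compound 1, `CC(C)n1cnc2c(N)ncnc21`: 4300 nM
compound 2, `CCC(C)n1cnc2ncnc(N)c21`: > 100000 nM

Among the measured compounds shown here, compound 1 holds the only numerical value in an assay on CHO cells for displacement of a labelled ligand from adenosine receptor A1 (Homo sapiens); a higher number here means a weaker inhibitor, a lower number a stronger inhibitor. In this assay compound 2 gives only > 100000 nM, which is a limit of the assay and not a number. One of the two values in this assay therefore sits at the limit of > 100000 nM in this assay, at which 1 of the 2 values shown sits. For the measured compounds named here, no step between two measured compounds that differ in a single place is available, so the effect of altering the group on the aromatic nitrogen remains untested within these data.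

Compound 3, `CC(C)Cn1cnc2c(N)ncnc21`, differs from compound 1 by isobutyl in place of isopropyl on an aromatic nitrogen. Going by the values given here, with no measured step of this kind, the expectation stays near the starting point: the step of a 1.3-fold higher number from compound 1 to compound 3 (0.11 log units; within the scatter) is expected to stay within the usual scatter or to weaken binding slightly. For compound 3 the estimated inhibition constant is 5500 nM, with a range from 1500 nM to 20000 nM.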

Compound 3, inhibition constant: > 100000 nM
Compound 3: no number, only a limit; the forecaster's own chance of this, stated with the estimate: 10%; middle value at least 18-fold (1.25 log units) from the limit.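

In this assay, among the compounds shown here, isobutyl in place of isopropyl on an aromatic nitrogen gives an at least 23-fold higher number from compound 1 to compound 3 (1.36 log units; beyond the scatter), the first single-place step and the first direct sign that binding is sensitive to the group at this position. The reading for compound 3 is a limit and not a number, so the step fixes only a minimum size, and isobutyl cannot be ranked any more finely. Readings in this assay now cluster at the top of the range, and compound 1 remains the only compound with a numerical value: the limit of > 100000 nM in this assay, at which 2 of the 3 values shown sit.

As far as these compounds go, whether a smaller group such as methyl or ethyl on this aromatic nitrogen would keep or improve binding remains open. Also open, from the compounds shown here alone, is how a cyclopropyl group or a chain carrying an amine would behave at the same position.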